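Swapping an acyl sulfonamide for a plain sulfonamide

The compounds below may be only part of what the source reports. "The series", "measured", "known", "first", "only" and "open" are said of these compounds alone.

Compound 3, `Cc1ccc(NC(=O)Nc2cc(-c3ccccc3C(=O)NS(=O)(=O)C(F)(F)F)ccc2N(CC(C)C)CC(C)C)cc1`, sits at the weak end of this small set. In an assay on HeLa cells for inhibition of Indoleamine 2,3-dioxygenase 1 (Homo sapiens), with stated times of 1 h and 18 h (a higher number here means a weaker inhibitor, a lower number a stronger inhibitor), compound 3 gives only a limit, > 1000 nM, so its true number is not known. The related compound 1, `Cc1ccc(NC(=O)Nc2cc(-c3ccccc3C(=O)O)ccc2N(CC(C)C)CC(C)C)cc1`, gives 13 nM, and compound 2, `Cc1ccc(NC(=O)Nc2cc(-c3ccccc3C(=O)NS(C)(=O)=O)ccc2N(CC(C)C)CC(C)C)cc1`, gives 661 nM. The step of a 51-fold higher number from compound 1 to compound 2 (1.71 log units; beyond the scatter) and the step of an at least 76-fold higher number from compound 1 to compound 3 (1.88 log units; beyond the scatter) both show that exchanging the hydroxy on the carbonyl carbon for a sulfonyl-bearing nitrogen costs a great deal; the step of an at least 1.5-fold higher number from compound 2 to compound 3 (0.17 log units; that floor lies within the scatter) adds little that can be told apart from noise, as the limit of > 1000 nM in this assay, at which 1 of the 3 values shown sits, caps what can be seen.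

Compound 4, `Cc1ccc(NC(=O)Nc2cc(-c3ccccc3NS(C)(=O)=O)ccc2N(CC(C)C)CC(C)C)cc1`, makes a different kind of change: methanesulfonamido in place of ((trifluoromethyl)sulfonyl)carbamoyl on an aromatic carbon. The carbonyl that carried the acid in compound 1 and the acyl sulfonamide in compounds 2 and 3 is gone, and the sulfonamide nitrogen now sits directly on the ring. Among the compounds with values here, no measured step covers removal of that carbonyl, so the only guide is that every departure from the acid of compound 1 has so far weakened inhibition. Compound 4 is therefore expected to remain weak, with the step that the limit leaves unreadable from compound 3 to compound 4 estimated as small. Compound 4 is estimated at 2500 nM, within 400 nM to 15000 nM.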

Compound 4, half-maximal inhibitory concentration: > 1000 nM
Compound 4: only a limit was reported; the forecaster's own chance of this, stated with the estimate: 60%; the middle value lies beyond the limit too.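

In this assay compound 4 gives only a limit, > 1000 nM, so setting the sulfonamide directly on the aromatic carbon, without the carbonyl, does not recover what was lost on leaving the acid. The step of an at least 76-fold higher number from compound 1 to compound 4 (1.88 log units; beyond the scatter) makes methanesulfonamido a third replacement of the carboxy group at this place that comes with a large loss, and among the compounds shown no replacement has kept the inhibition of the acid. The step of an at least 1.5-fold higher number from compound 2 to compound 4 (0.17 log units; that floor lies within the scatter) gives no firm separation, and the step between the two limits cannot be read, because the measurements stop at the same ceiling: the limit of > 1000 nM in this assay, at which 2 of the 4 values shown sit.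

The compounds shown leave open how far past that limit the true numbers of compound 3 and compound 4 lie, and so whether removing the carbonyl matters at all. They also leave open whether a different replacement for the carboxy group, such as a tetrazole ring, a hydroxamic acid or a primary amide, would stay close to compound 1 at 13 nM.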